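The source may report more compounds than this note shows. Statements on the series, on what has been measured and on what is new or still open speak of the compounds shown alone.

Of the compounds shown here, three built on a shared core have been tested in an ADME assay on J774 cells (Mus musculus) for cytotoxicity, read by MTT assay, with a stated time of 48 h, tested at 150 ug/mL; on this read-out lower numbers stand for a stronger effect and higher numbers for a weaker effect at the one concentration tested. Compound 1 `O=C(N/N=C/c1ccccc1)c1cnccn1` gives 100%. Compound 2 `O=C(N/N=C/c1cccc(Cl)c1)c1cnccn1`, which carries a chloro group, gives 100%, and compound 3 `O=C(N/N=C/c1ccc(Cl)cc1)c1cnccn1`, which also carries a chloro group, gives 56%. Compound 2 therefore stands level with compound 1, the two sharing the highest of the three numbers, while compound 3 sits well below both.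

The measured steps show how much a single change can matter. From compound 1 to compound 2, no change at the digits printed from compound 1 to compound 2 (within the scatter). From compound 1 to compound 3, a number 44 percentage points lower from compound 1 to compound 3 (beyond the scatter). Both steps are of the same kind, chloro in place of hydrogen on an aromatic carbon, yet one leaves the number unmoved and the other pulls it down sharply.

Compound 4 `O=C(N/N=C/c1cccc(F)c1)c1cnccn1` differs from compound 2 in one place: fluoro in place of chloro on an aromatic carbon. Among the measured compounds shown here, no measured step swaps chloro for fluoro, so the nearest guide is the step from compound 1 to compound 2, where a chloro group on an aromatic carbon left the number unchanged. The expected step in this assay is therefore none beyond the scatter, namely a number 3 percentage points lower from compound 2 to compound 4 (within the scatter). On that basis compound 4 is estimated at 97%, with a range from 80% to 100%.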

Compound 4, a percentage reported as activity, at one concentration (the size of the read-out at that concentration, not a potency): 40%
Compound 4: the middle estimate sits 57 percentage points above what was measured; the measured number lies below the stated range.
By their numbers in this assay, from the lowest: compound 4; then compound 3; then compounds 1 and 2 (each within the scatter of the next).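

At this one position, meta to a large group, the outcome depends on which halogen sits there: putting fluoro in place of chloro gives a number 60 percentage points lower from compound 2 to compound 4 (beyond the scatter) in this assay, so a carbon that looked indifferent from the chloro compound alone is not indifferent to every group. The comparison with the unsubstituted compound says the same thing, since fluoro in place of hydrogen gives a number 60 percentage points lower from compound 1 to compound 4 (beyond the scatter), while chloro in place of hydrogen on that same carbon gave no change at the digits printed from compound 1 to compound 2 (within the scatter), and on this read-out the lower number stands for the stronger effect. Why two single-atom groups with no ring, no charge and no counted hydrogen-bond donors or acceptors part so sharply here is something the available information does not explain.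

The compounds shown leave open whether a bromo, methoxy or amino group on this carbon would side with chloro, with fluoro, or with neither. They also leave open how fluoro would behave on the carbon that carries chloro in compound 3, and how the effect would change across a range of concentrations rather than at the single one tested.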